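The compounds below may be only part of what the source reports. "The series", "measured", "known", "first", "only" and "open" are said of these compounds alone.

Working notes on a small set of compounds measured in a functional assay on HEK293 cells (Homo sapiens), read by cAMP accumulation; on this read-out higher numbers stand for an effect only at larger amounts of compound and lower numbers for an effect already at smaller amounts. For the measured compounds named here, compound 1 `CCCC1=C(C(=O)OCc2ccc(C(=O)NCCCN(C)C)cc2)C(c2cccc(C)c2)NC(=O)N1` gives 1400 nM, the lowest number of the three measured so far. Compound 3 `COc1ccc(COC(=O)C2=C(C(C)C)NC(=O)NC2c2cccc(C)c2)cc1` gives 5800 nM, the nearest to compound 1, and compound 2 `CCCC1=C(C(=O)OCC)C(c2cc(C)cc(C)c2)NC(=O)N1` gives 9500 nM, the furthest from it. Both gaps from compound 1 lie beyond the scatter. Going by the values given here, compound 2 and compound 3 each differ from compound 1 in more than one place at once, so no step between measured compounds rests on a single change, and none is drawn here.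

Compound 4 `CCCC1=C(C(=O)OCc2ccc(C(=O)OC)cc2)C(c2cccc(C)c2)NC(=O)N1` is the next compound for this assay. It differs from compound 1 in one place only: methoxy in place of (3-(dimethylamino)propyl)amino on a carbonyl carbon Everything else in the two structures is shared.

Among the compounds with values here, no measured pair shows what a change of this kind does to the read-out, so the expectation rests on compound 1 alone. The step is expected to be modest, most likely a rise in the number, and it may well fall within the scatter: the expected step is a 1.8-fold higher number from compound 1 to compound 4 (0.25 log units; within the scatter). On that basis compound 4 is estimated at 2500 nM in this assay, with an expected range from 900 nM to 7000 nM.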

Compound 4, half-maximal effective concentration: 1000 nM
Estimate against measurement, compound 4: 2.5-fold (0.40 log units) above, within the range that was stated.
By their numbers in this assay, from the lowest: compounds 4 and 1 (each within the scatter of the next); then compounds 3 and 2 (each within the scatter of the next).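

In this assay, the series gains its first single-place step, a 1.4-fold lower number from compound 1 to compound 4 (0.15 log units; within the scatter), and it lies within the scatter. On this carbonyl carbon, methoxy in place of (3-(dimethylamino)propyl)amino therefore leaves the read-out unresolved from that of the parent, even though the group goes from 7 heavy atoms to 2, loses both nitrogens and goes from 1 hydrogen-bond donor to 0, so this pair gives no sign that the read-out depends on the longer chain. No measurement in hand bears on why the two compounds read alike.

Other groups on this carbonyl carbon remain open, such as a carboxylic acid, a simple primary amide or (2-(dimethylamino)ethyl)amino, any of which could show whether the read-out stays within the scatter beyond this one pair. Also open, on these data alone, is whether the same change gives a step of similar size with a longer chain in place of the propyl group on the shared core.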